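The source may report more compounds than this note shows. Statements on the series, on what has been measured and on what is new or still open speak of the compounds shown alone.

Going by the values given here, in a functional assay on MDA-MB-231 cells (Homo sapiens), read by microscopy and transwell migration, with a stated time of 24 h (on this read-out lower numbers stand for stronger inhibition and higher numbers for weaker inhibition), compound 2 (`C=CCn1c(-c2ccccc2)cs/c1=N\C(=O)c1ccccc1`) gives 1200 nM and holds the lower of the two numbers so far, while compound 1 (`C#CCn1c(-c2ccc(C)cc2C)cs/c1=N\C(=O)c1ccccc1`) gives 3890 nM as the higher one. Compound 3 (`C#CCn1c(-c2ccccc2)cs/c1=N\C(=O)c1ccccc1`) alters compound 2 in one place, with ethynyl in place of vinyl on a saturated chain carbon bound to an aromatic nitrogen. Compound 1 also carries the propargyl group but differs elsewhere too, so it offers no clean comparison. In this assay a small step is expected (a 1.3-fold higher number from compound 2 to compound 3 (0.10 log units; within the scatter)), toward a slightly higher number and probably within the scatter. The expected value for compound 3 is 1500 nM with an estimated range of 600 nM to 4000 nM for now.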

Compound 3, half-maximal inhibitory concentration: 2780 nM
Compound 3: middle estimate off by 1.9-fold (0.27 log units), on the low side; measured number inside the range.
By their numbers in this assay, from the lowest: compound 2; then compounds 3 and 1 (each within the scatter of the next).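

In this assay, allyl to propargyl on the shared core gives a 2.3-fold higher number from compound 2 to compound 3 (0.36 log units; beyond the scatter), so the vinyl or ethynyl end of this chain, on a saturated chain carbon bound to an aromatic nitrogen, does affect the number, with vinyl the better of the two. Phenyl in place of 2,4-dimethylphenyl on an aromatic carbon gives a 1.4-fold lower number from compound 1 to compound 3 (0.15 log units; within the scatter), which does not separate compound 1 from compound 3. Nothing measured here explains either result. On these data alone, whether a longer chain such as butyl, or a chain ending in an amine, would improve on allyl remains open.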